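The compounds below may be only part of what the source reports. "The series", "measured", "known", "first", "only" and "open" are said of these compounds alone.

Values measured in a physicochemical assay (on this read-out higher numbers stand for an effect only at larger amounts of compound and lower numbers for an effect already at smaller amounts), so far:

- compound 1 `COc1cc(/C=N/NC(=O)c2nn(-c3ccc(Cl)cc3Cl)c(-c3ccccc3)c2C)ccc1O` gives 2990000 nM
- compound 2 `COc1cc(/C=N/NC(=O)c2nn(-c3ccccc3)c(-c3ccccc3)c2C)ccc1O` gives 2460000 nM
- compound 3 `COc1cc(/C=N/NC(=O)c2nn(-c3ccc(Cl)c(Cl)c3)c(-c3ccc(Cl)cc3)c2C)ccc1O` gives 2600000 nM

These three values sit close together. Compound 3, at 2600000 nM, cannot be told apart from compound 1 or compound 2 on these numbers, as both gaps lie within the usual scatter of repeated measurements.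

The unmeasured compound 4 `COc1cc(/C=N/NC(=O)c2nn(-c3ccnc4cc(Cl)ccc34)c(-c3ccc(Cl)cc3)c2C)ccc1O` differs from compound 3 in one place, with 7-chloroquinolin-4-yl in place of 3,4-dichlorophenyl on an aromatic nitrogen of the shared core (7-chloroquinolin-4-yl in place of 3,4-dichlorophenyl on an aromatic nitrogen). Among the compounds with values here, the only measured step at this kind of place is a 1.2-fold lower number from compound 1 to compound 2 (0.08 log units; within the scatter), which puts phenyl in place of 2,4-dichlorophenyl on an aromatic nitrogen. That step is small and stays within the scatter. Within the data shown here, it is a single step, however, and no measured compound carries a ring with a hetero atom at this place, so the guidance is thin and points in neither direction. In this assay the expected outcome is no change at the digits printed from compound 3 to compound 4 (within the scatter), which means no step beyond the scatter. For compound 4 the estimated value is 2600000 nM, with an expected range from 1600000 nM to 4000000 nM.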

Compound 4, half-maximal effective concentration: 4590000 nM
For compound 4 the middle estimate is 1.8-fold (0.25 log units) below the measured one; the measured number lies above the stated range.
By their numbers in this assay, from the lowest: compounds 2, 3, 1 and 4 (each within the scatter of the next).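

In this assay, within the data shown here, the exchange of 3,4-dichlorophenyl for 7-chloroquinolin-4-yl gives a 1.8-fold higher number from compound 3 to compound 4 (0.25 log units; within the scatter), and this is the first reading at this position for a group with a ring that holds a hetero atom. It adds a second ring and a hydrogen-bond acceptor to the group on the aromatic nitrogen, yet compound 3 and compound 4 still cannot be told apart, just as the earlier exchange of 2,4-dichlorophenyl for phenyl gave a 1.2-fold lower number from compound 1 to compound 2 (0.08 log units; within the scatter) without leaving the scatter. Across these two steps, then, quite different aromatic groups at this position produce no change that stands clear of repeat-measurement noise, and nothing measured here offers an explanation for the size of the new step.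

The compounds shown leave open whether a group of another kind on this aromatic nitrogen, such as a chain ending in an amine or a carboxylic acid, would move the number beyond the scatter. From the compounds shown here alone, it also remains open whether 7-chloroquinolin-4-yl would give a similar step if a plain phenyl replaced the neighbouring 4-chlorophenyl group.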